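Capping the Piperazine Nitrogen with an Acetyl Group

The source may hold more compounds than are shown below. What is called first, only, known or untested is meant among the compounds shown, and "the series" means these compounds.

Measured so far:
Compound 1 `O=C1CCC(CCN2CC(N3CCOCC3=O)C2)(c2ccc(Cl)c(Cl)c2)CN1Cc1ccccc1` gives 2.51 nM in an assay on isolated protein (artery, Oryctolagus cuniculus) with Substance-P receptor (Homo sapiens) as the target; a higher number here means weaker binding, a lower number tighter binding.
Compound 2 `O=C1CCC(CCN2CC(N3CCNCC3)C2)(c2ccc(Cl)c(Cl)c2)CN1Cc1ccccc1` gives 5.01 nM in this assay.

Within the data shown here, compound 2 has the higher of the two numbers, yet the single step that separates the pair, a 2.0-fold higher number from compound 1 to compound 2 (0.30 log units; within the scatter), lies within the usual scatter, so on these data the two compounds cannot be told apart.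

Compound 3 `CC(=O)N1CCN(C2CN(CCC3(c4ccc(Cl)c(Cl)c4)CCC(=O)N(Cc4ccccc4)C3)C2)CC1` differs from compound 2 in one place: acetyl in place of hydrogen on an amine nitrogen in a ring. Among the measured compounds shown here, the only measured step that bears on this is a 2.0-fold higher number from compound 1 to compound 2 (0.30 log units; within the scatter), in which a ring carrying a carbonyl beside its nitrogen gave way to a plain piperazin-1-yl group and the number barely moved. Compound 3 brings a carbonyl back onto that ring nitrogen. From that small step, no change beyond the scatter is expected in this assay, with any drift more likely toward a lower number.

Compound 3 is therefore expected to give about 3.2 nM, in a range from 1.2 nM to 8.5 nM, which means an expected step of a 1.6-fold lower number from compound 2 to compound 3 (0.19 log units; within the scatter).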

Compound 3, dissociation constant: 1.59 nM
For compound 3 the middle estimate is 2.0-fold (0.30 log units) above the measured one; the measured number falls inside the stated range.
By their numbers in this assay, from the lowest: compounds 3, 1 and 2 (each within the scatter of the next, the first and the last beyond it).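

In this assay, among these compounds, acetyl in place of hydrogen on the ring amine nitrogen gives a 3.2-fold lower number from compound 2 to compound 3 (0.50 log units; beyond the scatter) and so provides the first step in this small set that lies beyond the scatter, showing that a change at this nitrogen can be read in this assay and that the hydrogen there can be replaced without loss of binding. Exchanging the whole group, by contrast, gives a 1.6-fold lower number from compound 1 to compound 3 (0.20 log units; within the scatter) and leaves 3-oxomorpholin-4-yl and 4-acetylpiperazin-1-yl indistinguishable here, even though acetyl separates compound 3 from compound 2. No measurement at hand explains what lies behind the acetyl step.

From the compounds shown here alone, whether a different group on that nitrogen, such as a plain methyl, a longer propanoyl chain or a methanesulfonyl group, would give a number close to that of compound 3 remains open. Going by these compounds, all three compounds share one core, so it is also open whether the acetyl step would carry over to a different core.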